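Methyl on the Amide Nitrogen: From Compound 2 to Compound 3

This account rests on a few compounds, and the source may have more. Where it says the series, first, only, none or still open, it means among the compounds named here.

Going by the values given here, compound 2 `N#Cc1cnc(NCc2cnccc2C(F)(F)F)cc1N[C@H]1CC[C@@H](C(N)=O)CC1` gives 400 nM in an assay on isolated protein for inhibition of protein kinase C delta type (Homo sapiens), read by TR-FRET, with a stated time of 2 h (a higher number here means a weaker inhibitor, a lower number a stronger inhibitor), the only number reported among the two measured compounds. Compound 1 `N#Cc1cnc(NCc2cnccc2C(F)(F)F)cc1NCCC1CCOCC1` reaches only a limit in this assay, reported as > 10000 nM. Among the compounds with values here, the single measured step is an at least 25-fold lower number from compound 1 to compound 2 (1.39 log units; beyond the scatter), which rests on the limit of > 10000 nM in this assay, at which 1 of the 2 values shown sits, and exchanges the whole side chain on the aromatic nitrogen.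

Compound 3 `CNC(=O)[C@H]1CC[C@@H](Nc2cc(NCc3cnccc3C(F)(F)F)ncc2C#N)CC1` differs from compound 2 by methyl in place of hydrogen on an amide-type nitrogen, a single carbon entering on an amide-type nitrogen whose other neighbour is the carbonyl carbon. Within the data shown here, no measured step touches that nitrogen: the one step available replaces 2-(oxan-4-yl)ethyl with 4-carbamoylcyclohexyl and carries no information on turning carbamoyl into methylcarbamoyl. Among the measured compounds shown here, with only that evidence, compound 3 is expected to stay within the scatter of compound 2 in this assay, the expected step being a 1.3-fold higher number from compound 2 to compound 3 (0.10 log units; within the scatter). Compound 3 is therefore estimated at 500 nM in this assay, with a range from 150 nM to 2000 nM.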

Compound 3, half-maximal inhibitory concentration: 1600 nM
The estimate for compound 3 lay 3.2-fold (0.51 log units) below the measured number; the measured number falls inside the stated range.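

Going by these compounds alone, the amide hydrogen of the carbamoyl group is not a silent place for substitution in this assay: a single added methyl gives a 4.0-fold higher number from compound 2 to compound 3 (0.60 log units; beyond the scatter), something the earlier compounds could not show, since their only step exchanged the whole side chain on the aromatic nitrogen. The 4-(methylcarbamoyl)cyclohexyl side chain still retains an advantage over 2-(oxan-4-yl)ethyl, with an at least 6.2-fold lower number from compound 1 to compound 3 (0.79 log units; beyond the scatter). Compound 1 stands at a limit, > 10000 nM, which is not a number, so that step gives only a bound: the limit of > 10000 nM in this assay, at which 1 of the 3 values shown sits.

The compounds shown leave open whether the number climbs further with a larger group on that nitrogen, such as ethyl or a second methyl, and whether a carboxylic acid or a primary amine in place of the carbamoyl would match compound 2 or improve on it. They also give no measured property that would explain the cost of this one methyl, so the step stands as an observation on a single pair.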